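From 4-methylbenzyl to 4-methoxybenzyl: notes on the series

This account rests on a few compounds, and the source may have more. Where it says the series, first, only, none or still open, it means among the compounds named here.

Of the compounds shown here, three with a shared core have been read in a functional assay on MGC-803 cells (Homo sapiens) for inhibition, read by MTT assay, with a stated time of 72 h; a lower number here means a stronger inhibitor, a higher number a weaker inhibitor. Compound 1 `Cc1cc(N2CC[C@@H](C)[C@@H](N(C)c3ncnc4[nH]ccc34)C2)n2nc(SCc3ccc(Cl)cc3)nc2n1` gives 16000 nM. Compound 2 `Cc1cc(N2CC[C@@H](C)[C@@H](N(C)c3ncnc4[nH]ccc34)C2)n2nc(SCc3csc4ccc(Cl)cc34)nc2n1` gives only a limit of the assay, > 100000 nM. Compound 3 `Cc1ccc(CSc2nc3nc(C)cc(N4CC[C@@H](C)[C@@H](N(C)c5ncnc6[nH]ccc56)C4)n3n2)cc1` gives 5860 nM, the lowest reading of the three, and its distance to the others is beyond the scatter.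

Compound 4 `COc1ccc(CSc2nc3nc(C)cc(N4CC[C@@H](C)[C@@H](N(C)c5ncnc6[nH]ccc56)C4)n3n2)cc1` carries methoxy in place of methyl on an aromatic carbon, para to a large group (methoxy in place of methyl on an aromatic carbon). For the measured compounds named here, no methoxy analogue has been measured, so the evidence is indirect. The closest guide is a 2.7-fold lower number from compound 1 to compound 3 (0.44 log units; beyond the scatter), with methyl in place of chloro on the same aromatic carbon, a modest change in size. The other two steps, an at least 6.2-fold higher number from compound 1 to compound 2 (0.79 log units; beyond the scatter) and an at least 17-fold lower number from compound 2 to compound 3 (1.23 log units; beyond the scatter), exchange the whole aromatic group and rest on a limit, so they bear only weakly on so small a change. A step no larger than the modest one is therefore expected in this assay, most likely within the scatter and with a slight lean towards a higher number.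

The expected outcome is a 1.4-fold higher number from compound 3 to compound 4 (0.14 log units; within the scatter). For compound 4 the estimated value is 8000 nM, with an expected range of 2800 nM to 24000 nM.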

Compound 4, half-maximal inhibitory concentration: 15200 nM
Beside the measured number, compound 4's estimate is 1.9-fold (0.28 log units) below it; measured number inside the range.
By their numbers in this assay, from the lowest: compound 3; then compounds 4 and 1 (each within the scatter of the next). At a limit, above all of these: compound 2.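

For the compounds shown here, at this place on the benzyl ring, para to a large group, the exchange of methyl for methoxy is not silent in this assay: the series shows a 2.6-fold higher number from compound 3 to compound 4 (0.41 log units; beyond the scatter) and so gives the first direct reading for a methoxy group here. Chloro and methoxy at this place cannot be told apart, with a 1.1-fold lower number from compound 1 to compound 4 (0.02 log units; within the scatter) between them, and the methyl of compound 3 is the only one of these three groups whose reading lies beyond the scatter of both others. Replacing the 5-chloro-1-benzothiophen-3-yl group gives an at least 6.5-fold lower number from compound 2 to compound 4 (0.81 log units; beyond the scatter) as a bound only, and the reading of compound 2 is a limit of the assay, not a number: the limit of > 100000 nM in this assay, at which 1 of the 4 values shown sits.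

The compounds shown leave open whether methyl is the exception at this place or whether other groups, such as ethyl, hydroxy or an amine, read like it or like chloro and methoxy. From the compounds shown here alone, they also leave open how the unsubstituted benzyl group reads, so the step of each of these groups from plain hydrogen at this place remains unknown.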